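Benzyl(ethyl)amino replacing the bis(dimethylaminoethyl)amino arm

The source may hold more compounds than are shown below. What is called first, only, known or untested is meant among the compounds shown, and "the series" means these compounds.

Measured compounds:
compound 1 `CN(C)CCN(CCN(C)C)c1ccc(C(=O)N2CCc3ccc(OS(N)(=O)=O)cc3C2)cc1`, 15.9%
compound 2 `NS(=O)(=O)Oc1ccc2c(c1)CN(C(=O)c1cccc(N3CCN(c4ncccn4)CC3)c1)CC2`, 24.4%
compound 3 `CCN(Cc1ccccc1)Cc1ccc(CN2CCc3ccc(OS(N)(=O)=O)cc3C2)cc1`, 17%

In an assay on HEK293 cells for inhibition of Steryl-sulfatase (Homo sapiens), tested at 1 uM (on this read-out lower numbers stand for a weaker effect and higher numbers for a stronger effect at the one concentration tested), compound 1 gives the low end of the three numbers, yet the nearest, compound 3, and the furthest, compound 2, both lie within the usual scatter of it, so the three cannot be ordered.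

Compound 4 `CCN(Cc1ccccc1)c1ccc(C(=O)N2CCc3ccc(OS(N)(=O)=O)cc3C2)cc1` differs from compound 1 in one place: benzyl(ethyl)amino in place of bis(2-(dimethylamino)ethyl)amino on an aromatic carbon. The entering group is the same one carried by compound 3, which sits within scatter of compound 1 in this assay, so no step beyond the scatter is expected here in either direction.

Compound 4 is therefore expected to give about 18% in this assay, between 6% and 32%, a step of a number 2.1 percentage points higher from compound 1 to compound 4 (within the scatter).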

Compound 4, a percentage reported as inhibition, at one concentration (the size of the read-out at that concentration, not a potency): 83.6%
Compound 4: middle estimate off by 65.6 percentage points, on the low side; the whole stated range lies below it.
By their numbers in this assay, from the lowest: compounds 1, 3 and 2 (each within the scatter of the next); then compound 4.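

Among the compounds shown here, this position is not silent: in this assay, benzyl(ethyl)amino in place of bis(2-(dimethylamino)ethyl)amino on an aromatic carbon, para to a large group, gives a number 67.7 percentage points higher from compound 1 to compound 4 (beyond the scatter) as the only step beyond the scatter. The change removes two dimethylamino-bearing chains and brings in one six-membered aromatic ring of carbon only, with fewer hydrogen-bond acceptors. Nothing measured here accounts for the step.

As far as these compounds go, whether the benzyl or the ethyl arm carries the step remains open. Dibenzylamino and plain benzylamino at this place would separate the two.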